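Trimming a Methyl from the Amide of Compound 3

The source may report more compounds than this note shows. Statements on the series, on what has been measured and on what is new or still open speak of the compounds shown alone.

In an assay on isolated protein for inhibition of Gonadotropin-releasing hormone receptor (Rattus norvegicus) (on this read-out higher numbers stand for weaker inhibition and lower numbers for stronger inhibition), compound 1 `CCCn1c(SCc2cc([N+](=O)[O-])ccc2OC)nc2cc(NC(=O)NC(C)(C)C)ccc21` gives 120 nM. Compound 2 `CCCn1c(SCc2cc([N+](=O)[O-])ccc2OC)nc2cc(NC(=O)NC(C)(C)C)cc(C(=O)OC)c21` in this assay gives 280 nM; the step of a 2.3-fold higher number from compound 1 to compound 2 (0.37 log units; beyond the scatter) is modest but beyond the scatter. Compound 3 `CCCn1c(SCc2cc([N+](=O)[O-])ccc2OC)nc2cc(NC(=O)NC(C)(C)C)cc(C(=O)N(C)C)c21` in this assay gives 200 nM, the second highest of the three numbers, with compound 2 nearest and compound 1 furthest, both within the scatter. Compound 4 `CCCn1c(SCc2cc([N+](=O)[O-])ccc2OC)nc2cc(NC(=O)NC(C)(C)C)cc(C(=O)NC)c21` differs from compound 3 by hydrogen in place of methyl on an amide-type nitrogen. The step that bears most on this is a 1.4-fold lower number from compound 2 to compound 3 (0.15 log units; within the scatter), a change on the same carbonyl group, alongside a 1.7-fold higher number from compound 1 to compound 3 (0.22 log units; within the scatter); both stayed within the scatter. No step beyond the scatter is therefore expected in this assay. Compound 4 is expected at 200 nM, between 100 nM and 400 nM, meaning an expected step of no change at the digits printed from compound 3 to compound 4 (within the scatter).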

Compound 4, half-maximal inhibitory concentration: 23 nM
For compound 4 the middle estimate is 8.7-fold (0.94 log units) above the measured one; the measured number lies below the stated range.
By their numbers in this assay, from the lowest: compound 4; then compounds 1, 3 and 2 (each within the scatter of the next, the first and the last beyond it).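

In this assay, the amide nitrogen turns out to be highly sensitive: hydrogen in place of methyl gives an 8.7-fold lower number from compound 3 to compound 4 (0.94 log units; beyond the scatter), although the earlier change on this carbonyl carbon stayed within the scatter. Methylcarbamoyl also gives a 12-fold lower number from compound 2 to compound 4 (1.09 log units; beyond the scatter) and a 5.2-fold lower number from compound 1 to compound 4 (0.72 log units; beyond the scatter), so on this aromatic carbon it is the only group shown that improves beyond the scatter on hydrogen. No measurement here explains why the amide hydrogen matters so much.

As far as these compounds go, whether an unsubstituted carboxamide or a longer chain such as ethyl on the nitrogen would keep the number this low remains open.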